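Thiourea in place of urea at the ring nitrogen

The source may report more compounds than this note shows. Statements on the series, on what has been measured and on what is new or still open speak of the compounds shown alone.

Three compounds share one core and were tested in a functional assay on HeLa cells (Homo sapiens) for antiproliferative activity, with a stated time of 24 h; a higher number here means a weaker inhibitor, a lower number a stronger inhibitor. Compound 1, `NC(=O)c1c(NC(=O)c2ccccc2Cl)sc2c1CCN(Cc1ccc(Cl)cc1)C2`, gives only a limit, > 50000 nM, which is where the assay stops rather than a number. Compound 2, `NC(=O)c1c(NC(=O)c2ccccc2F)sc2c1CCN(Cc1cccc(Cl)c1)C2`, gives 49500 nM. Compound 3, `NC(=O)c1c(NC(=O)c2ccccc2Cl)sc2c1CCN(C(=O)Nc1ccccc1Cl)C2`, gives 45400 nM. Compound 3 is one of the two compounds with a real number, and its distance from compound 2 is within the usual scatter, so the two cannot be told apart. For the measured compounds named here, the one step that ends at compound 3 is an at least 1.1-fold lower number from compound 1 to compound 3 (0.04 log units; that floor lies within the scatter), and since compound 1 sits at the limit of > 50000 nM in this assay, at which 1 of the 3 values shown sits, the true size of that step is unknown but could be small.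

Compound 4, `NC(=O)c1c(NC(=O)c2ccccc2Cl)sc2c1CCN(C(=S)Nc1c(Cl)cccc1Cl)C2`, is not yet measured. It differs from compound 3 in one place: a group of 11 heavy atoms (7 carbon, 1 nitrogen, 1 sulfur, 2 chlorine; one six-membered aromatic ring of carbon only) in place of a group of 10 heavy atoms (7 carbon, 1 nitrogen, 1 oxygen, 1 chlorine; one six-membered aromatic ring of carbon only), on an amine nitrogen in a ring. Going by the values given here, the only measured step at that same amine nitrogen in a ring is the one from compound 1 to compound 3, whose floor lies within the scatter, so a change at this position gives no sign of moving the number far. Compound 4 is therefore expected to show a 1.0-fold lower number from compound 3 to compound 4 (0.00 log units; within the scatter), that is, no step beyond the scatter. For compound 4 the estimate in this assay is 45000 nM, within a range from 20000 nM to 100000 nM.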

Compound 4, half-maximal inhibitory concentration: 26500 nM
Estimate against measurement, compound 4: 1.7-fold (0.23 log units) above, within the range that was stated.
By their numbers in this assay, from the lowest: compounds 4, 3 and 2 (each within the scatter of the next). At a limit, above all of these: compound 1.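

In this assay, the swap on the amine nitrogen in a ring gives a 1.7-fold lower number from compound 3 to compound 4 (0.23 log units; within the scatter); the entering group has sulfur where the leaving group has oxygen and carries a second chlorine, yet this double change stays within the scatter. Replacing the 4-chlorobenzyl group of compound 1 with the same entering group gives an at least 1.8-fold lower number from compound 1 to compound 4 (0.27 log units; that floor lies within the scatter), so this comparison also offers no firm sign of a real gain, although its true size could be larger than that floor. Compound 1 stands at a limit, not a number: the limit of > 50000 nM in this assay, at which 1 of the 4 values shown sits.

Sulfur and the second chlorine arrive together, so the compounds shown do not separate what each contributes, and a thiourea bearing a single chlorine on the same aromatic ring would be needed to tell them apart. Going by these compounds, it also remains open whether a different kind of group on this nitrogen, such as a simple acetyl or a longer chain ending in an amine, would move the number in this assay beyond the scatter.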